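The source may report more compounds than this note shows. Statements on the series, on what has been measured and on what is new or still open speak of the compounds shown alone.

Compound 1 `O=c1n(Cc2cc3cnccc3n2CCCC(F)(F)F)c2cnccc2n1C1CC1` gives in an ADME assay on HeLa cells (Homo sapiens) for cytotoxicity, read by ATP content, with a stated time of 3 days; a lower number here means that less compound is tolerated, a higher number that more compound is tolerated > 50000 nM, which is a limit of the assay.
Compound 2 `O=c1n(Cc2nc3nc(Cl)ccc3n2CCCCO)c2cnccc2n1C1CC1` gives in this assay > 50000 nM, again a limit of the assay.
Compound 3 `CS(=O)(=O)CCCn1c(Cn2c(=O)n(C3CC3)c3ccncc32)cc2cc(C(F)(F)F)ccc21` gives in this assay > 50000 nM, also a limit of the assay.

Compound 3 therefore stands only at a limit, and it shares that with every other measured compound, since all three values sit at the limit of > 50000 nM in this assay, at which 3 of the 3 values shown sit. The step to compound 4 `CS(=O)(=O)CCCn1c(Cn2c(=O)n(C3CC3)c3ccncc32)cc2ccccc21` is small: hydrogen in place of trifluoromethyl on an aromatic carbon. Going by the values given here, with no measured step to lean on, no change beyond the usual scatter in this assay is expected in either direction. Compound 4 is thus estimated to give about 60000 nM in this assay, within a range from 25000 nM to 150000 nM, most likely reported as a limit again. That expectation amounts to a step that the limit leaves unreadable from compound 3 to compound 4.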

Compound 4, half-maximal cytotoxic concentration: > 100000 nM
Compound 4 ended at the assay's limit; the forecaster's own chance of this, stated with the estimate: 85%; middle value at least 1.6-fold (0.22 log units) away from the limit.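

Going by these compounds alone, compound 3 and compound 4 both stand at limits of this assay, so no step between them can be read. The compounds shown leave open whether hydrogen in place of trifluoromethyl changes the result in this assay at all.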